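The compounds below may be only part of what the source reports. "The series", "measured", "known", "first", "only" and "open" are said of these compounds alone.

Compound 1, `COc1ccc2nc(Cl)c(/C=C3\SC(=S)NC3=O)cc2c1`, was tested in a toxicity assay on A549 cells (Homo sapiens) for cytotoxicity, read by MTT assay, with a stated time of 48 h; a lower number here means a stronger inhibitor of growth, a higher number a weaker inhibitor of growth. In this assay compound 1 gives > 100 ug/mL, which is a limit of the assay and not a number. Compound 2, `CCOc1ccc2nc(Cl)c(/C=C3\SC(=S)NC3=O)cc2c1`, gives > 100 ug/mL, again a limit rather than a number. Compound 3, `Cc1cccc2cc(/C=C3\SC(=S)N(CC(=O)O)C3=O)c(Cl)nc12`, gives > 100 ug/mL, also a limit. Because all three values sit at the limit of > 100 ug/mL in this assay, at which 3 of the 3 values shown sit, nothing here pins down where compound 1 stands beyond that limit. Going by the values given here, the one step between two compounds that differ in a single place, a step that the two limits leave unreadable from compound 1 to compound 2, is therefore unreadable in size, since both ends are limits.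

Compound 4, `O=C1NC(=S)S/C1=C\c1cc2cc(F)ccc2nc1Cl`, is not yet measured. It differs from compound 1 in one place: fluoro in place of methoxy on an aromatic carbon. Among the compounds with values here, no measured step touches a fluoro group, so the data give no direction and no size for this replacement; the only guide is that every compound measured so far sits at the same limit. For compound 4 the expected step is a step that the limit leaves unreadable from compound 1 to compound 4, with the result most likely reported once more as a limit rather than a number. The estimate for compound 4 is 150 ug/mL, with a range from 60 ug/mL to 400 ug/mL.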

Compound 4, concentration for 50% growth inhibition: > 100 ug/mL
Compound 4: a limit, no number; the forecaster's own chance of this, stated with the estimate: 75%; the middle value does not contradict the limit.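

In this assay compound 4 gives > 100 ug/mL, which is a limit and not a number. The steps from compound 1 and compound 2 to compound 4 cannot be read, because all the compounds end at the same limit: the limit of > 100 ug/mL in this assay, at which 4 of the 4 values shown sit. The compounds shown leave open whether methoxy, ethoxy or fluoro makes any difference to growth inhibition.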